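The compounds below may be only part of what the source reports. "The series", "measured", "known", "first", "only" and "open" are said of these compounds alone.

Compound 1, `Cc1cc(=O)oc2cc(OCCCn3cc(CNC(=O)CCCCC4CCSS4)nn3)ccc12`, gives 75.4% in a functional assay on PC-12 cells (Rattus norvegicus) for cytotoxicity, read by MTT assay, with stated times of 3 h and 2 h, tested at 50 uM; a lower number here means a weaker effect, a higher number a stronger effect of the compound at the concentration tested.
Compound 2, `O=C(CCCCC1CCSS1)NCc1cn(CCCOc2ccc3cc(-c4ccccc4)c(=O)oc3c2)nn1`, gives 23.1% in this assay.

Of the compounds shown here, two have been measured so far, and they sit far apart. Compound 2 has the lower of the two numbers; compound 1 stands higher by a margin that goes well beyond the usual scatter of this kind of measurement. Both compounds share the same core, a coumarin-like fused ring carrying a chain to a triazole and on to a cyclic disulfide amide; they differ only in the substituent on that fused ring, a methyl in compound 1 and a phenyl in compound 2.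

Compound 3, `O=C(CCCCC1CCSS1)NCc1cn(CCCOc2ccc3cc(-c4ccc(Cl)c(Cl)c4)c(=O)oc3c2)nn1`, keeps the framework of compound 2 and changes one thing: 3,4-dichlorophenyl in place of phenyl on an aromatic carbon. Among the measured compounds shown here, no measured pair shows this particular change, so there is no step in hand to guide an expectation, and the difference between compound 1 and compound 2 concerns a different substituent altogether. With that in mind, the step from compound 2 to compound 3 is expected to be modest, a number 8.9 percentage points higher from compound 2 to compound 3 (within the scatter), leaning slightly upward but not clearly beyond the scatter. Compound 3 is therefore estimated at 32%, within a range from 12% to 60%.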

Compound 3, a percentage reported as activity, at one concentration (the size of the read-out at that concentration, not a potency): 54.8%
Beside the measured number, compound 3's estimate is 22.8 percentage points below it; the measured number falls inside the stated range.
By their numbers in this assay, from the lowest: compound 2; then compound 3; then compound 1.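

In this assay, among the compounds shown here, the only change, 3,4-dichlorophenyl in place of phenyl on an aromatic carbon, comes with a number 31.7 percentage points higher from compound 2 to compound 3 (beyond the scatter) and that step is large. For the compounds shown here, it shows that the number read here responds to what the phenyl ring itself carries, something no earlier pair of measured compounds could speak to, and the two added chlorine atoms are the whole of the difference, while the shared core, the chain and the cyclic disulfide amide stay as they were. Nothing measured here explains why the number moves, so the step stands as a plain observation.

As far as these compounds go, whether a single chlorine on the phenyl ring would give a step of similar size, or whether both chlorine atoms are needed, stays open with these compounds. Also open, from the compounds shown here alone, is how other groups on that phenyl ring, such as a methoxy group, a nitrile or an amine, would read in this assay and whether the number follows any simple trend across such groups.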